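Swapping the side-chain group of compound 3 in a tail flick test

The source may hold more compounds than are shown below. What is called first, only, known or untested is meant among the compounds shown, and "the series" means these compounds.

Compound 1, `O=C(CN(c1ncnc2c1ncn2C1CCCCO1)C1CC1)N[C@@H](CCC(=O)OCc1ccccc1)C(=O)OCc1ccccc1`, gives 14.1%. Compound 2, `O=C(CN(c1ncnc2c1ncn2C1CCCCO1)C1CC1)NCC(=O)OCc1ccccc1`, gives 7.26%. Compound 3, `NC(=O)C[C@H](NC(=O)CN(c1ncnc2c1ncn2C1CCCCO1)C1CC1)C(=O)OCc1ccccc1`, gives 21.7%. All three numbers come from a functional assay on the whole organism (Tail, strain ICR) with Mus musculus as the target, in the tail flick test, with a stated time of 150 min, at a dose of 25 umol/kg by the oral route; on this read-out higher numbers stand for a stronger effect at the one dose given and lower numbers for a weaker effect.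

For the measured compounds named here, on these numbers compound 3 gives the largest reading of the three, yet the step of a number 7.6 percentage points higher from compound 1 to compound 3 (within the scatter) stays within the usual scatter, and only the step of a number 14.4 percentage points higher from compound 2 to compound 3 (beyond the scatter) stands beyond it. Compound 4, `N=C(N)NCCC[C@H](NC(=O)CN(c1ncnc2c1ncn2C1CCCCO1)C1CC1)C(=O)OCc1ccccc1`, has not been measured in this assay. It differs from compound 3 by a group of 6 heavy atoms (3 carbon, 3 nitrogen; no ring) in place of a group of 3 heavy atoms (1 carbon, 1 nitrogen, 1 oxygen; no ring), on a saturated chain carbon, two bonds along the chain from an amide-type nitrogen and a carbonyl carbon.

Going by the values given here, two measured steps bear on this change. The step of a number 7.6 percentage points higher from compound 1 to compound 3 (within the scatter) swapped one group for another at the same place and remained within the scatter. The step of a number 14.4 percentage points higher from compound 2 to compound 3 (beyond the scatter) put a side chain where a hydrogen had been and was modest but beyond the scatter. Since a swap of one side-chain group for another at this place has so far given nothing beyond the scatter, the step of a number 3.7 percentage points lower from compound 3 to compound 4 (within the scatter) is expected to stay within the scatter as well. Compound 4 is therefore estimated at 18%, with a range from 7% to 30%.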

Compound 4, a percentage reported as activity, at one dose (the size of the read-out at that dose, not a potency): 19.6%
The estimate for compound 4 lay 1.6 percentage points below the measured number; measured number inside the range.
By their numbers in this assay, from the lowest: compounds 2, 1, 4 and 3 (each within the scatter of the next, the first and the last beyond it).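

In this assay, the group of 6 heavy atoms that replaces carbamoyl gives a step, a number 2.1 percentage points lower from compound 3 to compound 4 (within the scatter), so a longer group with no common name and more hydrogen-bond donors still does not separate from carbamoyl at this place. The step of a number 12.3 percentage points higher from compound 2 to compound 4 (beyond the scatter) repeats what compound 3 showed, so a gain over hydrogen at this chain carbon is no longer tied to a single side chain, though compound 1 goes against this pattern, as its own step to compound 2 stays within the scatter; the step of a number 5.5 percentage points higher from compound 1 to compound 4 (within the scatter) likewise shows that exchanging the ring-bearing benzyl ester group for a group with no ring leaves no separation. Nothing available explains these readings.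

As far as these compounds go, whether a free carboxylic acid, a simple amine or a longer chain at this carbon would read differently from these side chains remains open. With a single dose and a single time, the readings also leave open how these compounds compare in potency or duration.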